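The source may report more compounds than this note shows. Statements on the series, on what has been measured and on what is new or still open speak of the compounds shown alone.

Compounds measured so far:
Compound 1, `CCCCCCN(Cc1ccc(C(=O)NO)cc1)c1ncc(-c2ccc(C)cc2)s1` — in a functional assay on PC-3 cells (Homo sapiens) for antiproliferative activity, read by MTT assay, with a stated time of 48 h (a higher number here means a weaker inhibitor of growth, a lower number a stronger inhibitor of growth), compound 1 gives 5270 nM.
Compound 2, `Cc1ccc(-c2cnc(N(Cc3ccc(C(=O)NO)cc3)CC(C)C)s2)cc1` — in this assay compound 2 gives 9340 nM.
Compound 3, `Cc1ccc(OCCCN(Cc2ccc(C(=O)NO)cc2)c2ncc(-c3ccc(C)cc3)s2)cc1` — in this assay compound 3 gives 9330 nM.

Compound 3 sits together with the other two: the change a 1.0-fold lower number from compound 2 to compound 3 (0.00 log units; within the scatter) is flat, and a 1.8-fold higher number from compound 1 to compound 3 (0.25 log units; within the scatter) also stays inside the scatter, so no one of the three can be called the stronger or weaker inhibitor of growth on these numbers.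

Compound 4, `CCCN(Cc1ccc(C(=O)NO)cc1)c1ncc(-c2ccc(C)cc2)s1`, is not yet measured. It differs from compound 3 in one place: hydrogen in place of 4-methylphenoxy on a saturated chain carbon, three bonds along the chain from a nitrogen on an aromatic ring. Read the other way round, this is exactly the step that separates compound 1 from compound 3, where a 1.8-fold higher number from compound 1 to compound 3 (0.25 log units; within the scatter) was seen. Compound 4 is in fact the same structure as compound 1, so that step bears directly on the question, and the flat step a 1.0-fold lower number from compound 2 to compound 3 (0.00 log units; within the scatter) suggests that this part of the molecule moves the number little in any case. The expectation is therefore a small shift back toward the number of compound 1, a step of about a 1.7-fold lower number from compound 3 to compound 4 (0.23 log units; within the scatter), which is not beyond the scatter.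

For compound 4 in this assay the estimated value is 5500 nM, with a likely range from 2500 nM to 12000 nM.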

Compound 4, concentration for 50% growth inhibition: 9160 nM
Compound 4: middle estimate off by 1.7-fold (0.22 log units), on the low side; low and high end bracket the measured number.
By their numbers in this assay, from the lowest: compounds 1, 4, 3 and 2 (each within the scatter of the next).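

Taking away the whole 4-methylphenoxy group, with its 8 heavy atoms and its aromatic ring, does not shift the result in this assay: the step is a 1.0-fold lower number from compound 3 to compound 4 (0.01 log units; within the scatter). For the compounds shown here, until now this place had been seen only with a chain or with that group, and compound 4 shows that a bare propyl end gives a number within the scatter of the bulkier 3-(4-methylphenoxy)propyl. Compound 4 also stays within the scatter of the other two chains, with a 1.0-fold lower number from compound 2 to compound 4 (0.01 log units; within the scatter) and a 1.7-fold higher number from compound 1 to compound 4 (0.24 log units; within the scatter), so none of the four substituents on this nitrogen can be ranked in this assay, and nothing available explains why the result is so flat.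

All of the chains shown are built only from carbon, apart from the ether oxygen of compound 3, so it remains open whether an amine or a carboxylic acid on a saturated chain carbon, three bonds along the chain from a nitrogen on an aromatic ring, would move the number beyond the scatter. The compounds shown also leave open whether a change elsewhere in the shared core would have a larger effect than any change at this position.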